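A few compounds are considered here, and "the series" means these few. Any claim that something is new, unique, unknown or untested is made for them only; others in the source may bear on it.

Compound 1, `CN(C)c1nc2c(ncn2-c2ccccc2)c(=O)n1-c1ccccc1`: > 100000 nM
Compound 2, `CCCCN(CCCC)c1nc2c(ncn2-c2ccccc2)c(=O)n1-c1ccccc1`: 10000 nM

In a functional assay on OVCAR-3 cells (Homo sapiens) for cytotoxicity, read by MTT assay, with a stated time of 72 h (on this read-out lower numbers stand for stronger inhibition and higher numbers for weaker inhibition), compound 1 gives > 100000 nM, which is a limit of the assay rather than a number. Among the measured compounds shown here, compound 2 gives 10000 nM in this assay, and it is the only compound with a number; the other value shown sits at the limit of > 100000 nM in this assay, at which 1 of the 2 values shown sits. For the measured compounds named here, the single measured step, an at least 10-fold lower number from compound 1 to compound 2 (1.00 log units; beyond the scatter), came with dibutylamino in place of dimethylamino on an aromatic carbon.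

Compound 3, `CC(C)N(c1nc2c(ncn2-c2ccccc2)c(=O)n1-c1ccccc1)C(C)C`, differs from compound 2 by diisopropylamino in place of dibutylamino on an aromatic carbon. The entering group is the smaller of the two by the count given, so the change runs part of the way back toward compound 1. Going by the values given here, only the step from compound 1 to compound 2 bears on it, and it was in the direction of stronger inhibition as the group grew. A step in this assay toward weaker inhibition is therefore expected, of moderate size, with a real chance that only a limit is reported. For compound 3 a value of 30000 nM is expected, between 10000 nM and 100000 nM. That expected change amounts to a 3.0-fold higher number from compound 2 to compound 3 (0.48 log units; beyond the scatter).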

Compound 3, half-maximal inhibitory concentration: > 100000 nM
Compound 3: no number, only a limit; the forecaster's own chance of this, stated with the estimate: 35%; middle value at least 3.3-fold (0.52 log units) from the limit.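

In this assay compound 3 gives > 100000 nM, which is a limit and not a number. Even so, the change is readable as an at least 10-fold higher number from compound 2 to compound 3 (1.00 log units; beyond the scatter), so at this position, on an aromatic carbon between two ring nitrogen atoms, the gain seen with dibutylamino does not carry over to every larger amino group than dimethylamino, and the identity of the group matters, not only its heavy-atom count. The step between compound 1 and compound 3 cannot be read, because both values are limits: the limit of > 100000 nM in this assay, at which 2 of the 3 values shown sit.

The compounds shown do not separate the effect of chain length from that of branching at the carbon attached to the nitrogen. An unbranched dipropylamino group, a longer dihexylamino group or a ring amine such as piperidine would leave open how far this trend extends.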